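Amide swap on a naphthyl-pyridine acrylamide series

A few compounds are considered here, and "the series" means these few. Any claim that something is new, unique, unknown or untested is made for them only; others in the source may bear on it.

In a functional assay on HCT-116 cells (Homo sapiens) for inhibition, read by MTT assay, with a stated time of 72 h (on this read-out lower numbers stand for stronger inhibition of growth and higher numbers for weaker inhibition of growth), compound 1 `O=C(/C=C/c1ccncc1-c1ccc2[nH]ccc2c1)N1CCOCC1` gives "not determined" (no result reported), so no number is reported for it. Going by the values given here, compound 2 `O=C(/C=C/c1ccncc1-c1ccc2ccccc2c1)NC1CC1` gives 6180 nM in this assay, the only number available here, so it stands alone without comparison. Compound 3 `CN(C)C(=O)/C=C/c1ccncc1-c1ccc2ccccc2c1` differs from compound 2 by dimethylamino in place of cyclopropylamino on a carbonyl carbon. Among the compounds with values here, no step between measured compounds exists to guide this change, so the step of a 1.1-fold higher number from compound 2 to compound 3 (0.05 log units; within the scatter) is expected to stay within the usual scatter, with no clear direction. Compound 3 is therefore estimated at 7000 nM in this assay, with a range from 2500 nM to 20000 nM.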

Compound 3, concentration for 50% growth inhibition: 4540 nM
Compound 3: middle estimate off by 1.5-fold (0.19 log units), on the high side; measured number inside the range.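

In this assay, dimethylamino in place of cyclopropylamino on a carbonyl carbon gives a 1.4-fold lower number from compound 2 to compound 3 (0.13 log units; within the scatter), so the two compounds read alike. At this place, then, the number does not depend on the three-membered ring or on the hydrogen-bond donor of cyclopropylamino. No separate measurement bears on this result. Still open, on these data alone, is whether a larger or differently built group here, such as a 2-aminoethylamino group or a longer chain ending in a carboxylic acid, would move the number beyond the scatter.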